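A few compounds are considered here, and "the series" means these few. Any claim that something is new, unique, unknown or untested is made for them only; others in the source may bear on it.

Compounds measured in a functional assay (muscle tissue) with Cavia porcellus as the target; on this read-out higher numbers stand for an effect only at larger amounts of compound and lower numbers for an effect already at smaller amounts:
compound 1, `COC(=O)C1=C(C)N=C(C)/C(=C(\O)OC)C1c1cccc([N+](C)(C)C)c1`, 50100 nM
compound 2, `COC(=O)C1=C(C)N=C(C)/C(=C(\O)OC)C1c1ccccc1I`, 46.8 nM
compound 3, `COC(=O)C1=C(C)N=C(C)/C(=C(\O)OC)C1c1cccc(I)c1`, 41.7 nM

Compound 2 stands second highest of these three numbers. Its nearest neighbour is compound 3, with a 1.1-fold lower number from compound 2 to compound 3 (0.05 log units; within the scatter), so these two are indistinguishable here. Far away stands compound 1, whose 50100 nM lies well beyond the number of compound 2.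

The step to compound 4, `COC(=O)C1=C(C)N=C(C)/C(=C(\O)OC)C1c1cccc(F)c1`, changes the aromatic ring: 3-fluorophenyl in place of 2-iodophenyl on a saturated ring carbon. Among the measured compounds shown here, two measured steps bear on it. The move of the iodine atom from the 2- to the 3-position of the phenyl, a 1.1-fold lower number from compound 2 to compound 3 (0.05 log units; within the scatter), was without effect beyond the scatter. The exchange at that same position in a 1200-fold lower number from compound 1 to compound 3 (3.08 log units; beyond the scatter) was large, but it replaced a charged group, not one halogen by another. For the measured compounds named here, no measured pair shows iodine replaced by fluorine, so the size of that part of the step is open. Compound 4 is therefore expected to land near compound 2 and compound 3, perhaps somewhat higher, giving an estimated 3.2-fold higher number from compound 2 to compound 4 (0.51 log units; beyond the scatter). For compound 4 the expected value is 150 nM, within 30 nM to 800 nM.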

Compound 4, half-maximal effective concentration: 20.9 nM
Compound 4: middle estimate off by 7.2-fold (0.86 log units), on the high side; measured number below the stated range.
By their numbers in this assay, from the lowest: compounds 4, 3 and 2 (each within the scatter of the next, the first and the last beyond it); then compound 1.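

In this assay, the exchange of one halogen for another at this position, fluoro in place of iodo on an aromatic carbon, stays within the scatter, with a 2.0-fold lower number from compound 3 to compound 4 (0.30 log units; within the scatter), so the iodine atom can be given up without a clear change in the number. The combined change from 2-iodophenyl to 3-fluorophenyl goes just past the scatter, with a 2.2-fold lower number from compound 2 to compound 4 (0.35 log units; beyond the scatter), although neither of its two parts does so alone. With a 2400-fold lower number from compound 1 to compound 4 (3.38 log units; beyond the scatter), the large gap to the group of compound 1 recurs with fluorine as it did with iodine.

From the compounds shown here alone, whether an amine, a carboxylic acid or a methoxy group at this position would keep the number near these halogen compounds remains open, as does the standing of 2-fluorophenyl. Nothing given here accounts for these steps.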